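The source may report more compounds than this note shows. Statements on the series, on what has been measured and on what is new or still open speak of the compounds shown alone.

In a functional assay on CCRF-CEM cells (Homo sapiens) for inhibition (a higher number here means a weaker inhibitor, a lower number a stronger inhibitor), compound 1 (`O=C1/C(=C/c2cccc(Cl)c2)Cc2ccccc21`) gives 31800 nM and compound 2 (`O=C1CCCCC/C1=C\c1ccc(Cl)cc1`) gives 43500 nM as its half-maximal inhibitory concentration, two values within the usual scatter of each other. Among the measured compounds shown here, compound 2 thus stands level with the only other measured compound. Compound 3 (`COc1ccc(/C=C2\CCCCCC2=O)cc1`) carries methoxy in place of chloro on an aromatic carbon, para to a group of 9 heavy atoms (methoxy in place of chloro on an aromatic carbon). For the measured compounds named here, no measured pair shows such a swap, so no step beyond the scatter is expected. The expected change (a 1.1-fold lower number from compound 2 to compound 3 (0.06 log units; within the scatter)) is small. Compound 3 is expected at 38000 nM within an estimated range from 15000 nM to 90000 nM for now.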

Compound 3, half-maximal inhibitory concentration: 194000 nM
Beside the measured number, compound 3's estimate is 5.1-fold (0.71 log units) below it; measured number above the stated range.
By their numbers in this assay, from the lowest: compounds 1 and 2 (each within the scatter of the next); then compound 3.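

In this assay the swap of chloro for methoxy on this aromatic carbon brings a 4.5-fold higher number from compound 2 to compound 3 (0.65 log units; beyond the scatter) and gives the first clear separation among these compounds. What sits at this place, para to a group of 9 heavy atoms, can therefore change the number, and these two groups are not interchangeable here. No measurement shown accounts for this shift.

From the compounds shown here alone, whether fluoro, hydroxy or an amine at this place would stay close to chloro or to methoxy remains open. So does whether methoxy would have a similar effect on the core of compound 1.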